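Replacing a Nitro Group with Hydrogen in Compound 1

The source may report more compounds than this note shows. Statements on the series, on what has been measured and on what is new or still open speak of the compounds shown alone.

In a physicochemical assay for metabolic stability, read by HPLC, at pH 7.4 (a lower number here means that the compound disappears faster, a higher number that the compound lasts longer), compound 1 `COc1cc(NC(C)CCCNC(=O)Oc2ccc([N+](=O)[O-])cc2)c2ncccc2c1` gives 0.035 h, the lowest number among those measured. Compound 3 `COc1cc(NC(C)CCCNC(=O)Oc2ccc(Cl)cc2)c2ncccc2c1` holds the nearest number, 96 h. Chloro in place of nitro thus gives a large step, a 2700-fold higher number from compound 1 to compound 3 (3.44 log units; beyond the scatter). Compound 2 `COc1ccc(OC(=O)NCCCC(C)Nc2cc(OC)cc3cccnc23)cc1` reads > 720 h, which is a limit of the assay and not an exact number. Methoxy in place of nitro gives another large step, an at least 20000-fold higher number from compound 1 to compound 2 (4.31 log units; beyond the scatter), while chloro in place of methoxy gives a smaller one, an at least 7.5-fold lower number from compound 2 to compound 3 (0.87 log units; beyond the scatter).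

Compound 4 `COc1cc(NC(C)CCCNC(=O)Oc2ccccc2)c2ncccc2c1` has hydrogen in place of nitro on an aromatic carbon, para to a large group: hydrogen in place of nitro on an aromatic carbon. Both measured replacements of nitro at this place raised the number strongly, so a large rise is expected again. The expected result is an 8600-fold higher number from compound 1 to compound 4 (3.93 log units; beyond the scatter). For compound 4 the estimate is 300 h, with an expected range from 90 h to 1000 h.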

Compound 4, half-life: 288 h
For compound 4 the middle estimate is 1.0-fold (0.02 log units) above the measured one, and the stated range covers the measured number.
By their numbers in this assay, from the lowest: compound 1; then compound 3; then compound 4. At a limit, above all of these: compound 2.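

With hydrogen in this place, para to a large group, this assay shows a rise of the same large order as for the two other replacements of nitro, an 8200-fold higher number from compound 1 to compound 4 (3.92 log units; beyond the scatter), so the rise does not depend on a new group entering. The place still responds once nitro has left, since chloro and hydrogen differ from each other, a 3.0-fold higher number from compound 3 to compound 4 (0.48 log units; beyond the scatter). Compound 2 stands at a limit and not at an exact number, so methoxy and hydrogen can be compared only as a bound, an at least 2.5-fold lower number from compound 2 to compound 4 (0.39 log units; beyond the scatter), and this step's full size stays unknown: the limit of > 720 h in this assay, at which 1 of the 4 values shown sits.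

As far as these compounds go, only nitro, chloro, methoxy and hydrogen appear at this place, so the outcome with an amine or a carboxylic acid stays open. From the compounds shown here alone, the true half-life of compound 2 also remains open.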